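A few compounds are considered here, and "the series" means these few. Any claim that something is new, unique, unknown or untested is made for them only; others in the source may bear on it.

Measured so far in an assay on LtK cells with ATP-sensitive inward rectifier potassium channel 11 (Homo sapiens) as the target; on this read-out lower numbers stand for an effect already at smaller amounts and higher numbers for an effect only at larger amounts of compound:
- compound 1, `CC(C)OC(=O)Nc1c(C(O)(C(F)(F)F)C(F)(F)F)ccc2ccccc12`: 1160 nM
- compound 2, `Cc1ccccc1C(=O)Nc1c(C(O)(C(F)(F)F)C(F)(F)F)ccc2ccccc12`: 5550 nM
- compound 3, `O=C(Nc1c(C(O)(C(F)(F)F)C(F)(F)F)ccc2ccccc12)c1ccc(I)cc1`: 154 nM

Compound 3 stands at the lowest of the three numbers in this assay. Its nearest neighbour is compound 1 (a 7.5-fold lower number from compound 1 to compound 3 (0.88 log units; beyond the scatter)), its furthest is compound 2 (a 36-fold lower number from compound 2 to compound 3 (1.56 log units; beyond the scatter)). The two aryl amides thus sit far apart, and the carbamate of compound 1 lies between them (a 4.8-fold higher number from compound 1 to compound 2 (0.68 log units; beyond the scatter)).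

The next compound, compound 4, `O=C(Nc1c(C(O)(C(F)(F)F)C(F)(F)F)ccc2ccccc12)c1cccnc1`, keeps the shared core and the amide but exchanges the aryl group: pyridin-3-yl in place of 4-iodophenyl on a carbonyl carbon. No measured step removes iodine or introduces a ring nitrogen at this position, so the only guidance is that every change at the carbonyl carbon shown here has moved the number well beyond the scatter, and that compound 3 holds the lowest value. A step back towards the numbers of compound 1 and compound 2 is therefore expected rather than a further decrease, but its size is uncertain.

Compound 4 is estimated at 1500 nM (range 400 nM to 6000 nM), which would mean an expected step of a 9.7-fold higher number from compound 3 to compound 4 (0.99 log units; beyond the scatter).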

Compound 4, half-maximal effective concentration: 60 nM
Estimate against measurement, compound 4: 25-fold (1.40 log units) above; the measured number lies below the stated range.
By their numbers in this assay, from the lowest: compound 4; then compound 3; then compound 1; then compound 2.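

Read in this assay the lowest number now belongs to compound 4 (a 2.6-fold lower number from compound 3 to compound 4 (0.41 log units; beyond the scatter)), so on a carbonyl carbon whose other neighbour is the amide-type nitrogen, a low number requires neither iodine nor a ring of carbon only. The spread among the aryl amides also widens (a 93-fold lower number from compound 2 to compound 4 (1.97 log units; beyond the scatter)), and the carbamate is left further behind (a 19-fold lower number from compound 1 to compound 4 (1.29 log units; beyond the scatter)), though compound 2 still goes against any reading that aryl amides as a class give lower numbers than the carbamate of compound 1. The compounds show what the exchange does to the number, but no measurement bears on the reason for it.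

The effect of the ring nitrogen cannot be separated from the loss of iodine, since the two changes arrive together, and an unsubstituted phenyl on the same carbonyl carbon would be the group to divide them. Also open is whether the placing of the ring nitrogen matters, as the series shown holds neither pyridin-2-yl nor pyridin-4-yl.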